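The source may report more compounds than this note shows. Statements on the series, on what has been measured and on what is new or still open speak of the compounds shown alone.

Measured so far:
compound 1 `COc1cc2ncnc(-n3nc(-c4ccccn4)nc3N)c2cc1[N+](=O)[O-]`: > 13000 nM
compound 2 `Nc1nc(-c2ccccn2)nn1-c1ncnc2cc(N3CCNCC3)c([N+](=O)[O-])cc12`: "not determined" (no result reported)
compound 3 `COc1cc2ncnc(-n3nc(-c4ccccc4)cc3N)c2cc1OC`: "not determined" (no result reported)

In an ADME assay on BJ cells (Homo sapiens) for cytotoxicity, with a stated time of 72 h (on this read-out higher numbers stand for an effect only at larger amounts of compound and lower numbers for an effect already at smaller amounts), compound 1 gives > 13000 nM, which is a limit of the assay and not a number. Compound 2 and compound 3 carry no result in this assay, so compound 1 is the only anchor, and it sits at the limit of > 13000 nM in this assay, at which 1 of the 3 values shown sits. Among the compounds with values here, no step between two measured compounds exists in this set.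

Compound 4 `COc1cc2ncnc(-n3nc(-c4ccccn4)nc3N)c2cc1OCCNC(=O)OC(C)(C)C` is not yet measured. It differs from compound 1 in one place: 2-((tert-butoxycarbonyl)amino)ethoxy in place of nitro on an aromatic carbon. With only a limit to build on, the step from compound 1 to compound 4 is expected to stay within the scatter, a step that the limit leaves unreadable from compound 1 to compound 4. For compound 4 in this assay the estimate is 15000 nM, between 5000 nM and 50000 nM, most likely reported again as a limit.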

Compound 4, half-maximal effective concentration: > 15000 nM
Compound 4: no number, only a limit; the forecaster's own chance of this, stated with the estimate: 70%; the middle value lies on the limit itself.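

Compound 1 gives > 13000 nM, a limit and not a number. Compound 4 gives > 15000 nM, also a limit. Within the data shown here, no step between compound 1 and compound 4 can be read from these. The compounds shown leave open at what concentration either reaches its half-maximal effect.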